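A few compounds are considered here, and "the series" means these few. Any claim that something is new, unique, unknown or untested is made for them only; others in the source may bear on it.

Four compounds are compared here, and all carry the same core, differing in the aryl group on an oxygen on a saturated carbon. In a functional assay on HL-60 cells (Homo sapiens) for antiproliferative activity, read by MTT assay, with a stated time of 72 h (on this read-out lower numbers stand for stronger inhibition and higher numbers for weaker inhibition), compound 1 `NC1=NC2(CCOCC2)N(OCCCOc2ccc(F)cc2)C(N)=N1` gives 2380 nM. Compound 2 `Cc1cc(C)cc(OCCCON2C(N)=NC(N)=NC23CCOCC3)c1` gives 720 nM. Compound 3 `NC1=NC2(CCOCC2)N(OCCCOc2ccc(Cl)c(Cl)c2)C(N)=N1` gives 1240 nM, a value that lies within the scatter of both others, as a 1.9-fold lower number from compound 1 to compound 3 (0.28 log units; within the scatter) and a 1.7-fold higher number from compound 2 to compound 3 (0.24 log units; within the scatter) show. Only a 3.3-fold lower number from compound 1 to compound 2 (0.52 log units; beyond the scatter) goes beyond the scatter, and it is modest.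

Compound 4 `NC1=NC2(CCOCC2)N(OCCCOc2cc(Cl)c(Cl)cc2Cl)C(N)=N1` has not yet been measured. It departs from compound 3 by chloro in place of hydrogen on an aromatic carbon, which turns 3,4-dichlorophenyl into 2,4,5-trichlorophenyl. Among the compounds with values here, no measured step makes this exact change. The nearest evidence is the pair of steps that replace the 4-fluorophenyl group, namely a 1.9-fold lower number from compound 1 to compound 3 (0.28 log units; within the scatter) and a 3.3-fold lower number from compound 1 to compound 2 (0.52 log units; beyond the scatter), and neither is large. In this assay, therefore, only a small step is expected, leaning towards a lower number and probably not clearing the scatter. The expected change is a 1.6-fold lower number from compound 3 to compound 4 (0.19 log units; within the scatter). For compound 4 the estimated value is 800 nM, with an expected range from 300 nM to 2000 nM.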

Compound 4, half-maximal inhibitory concentration: 2360 nM
Beside the measured number, compound 4's estimate is 3.0-fold (0.47 log units) below it, and the stated range ends below it.
By their numbers in this assay, from the lowest: compounds 2, 3, 4 and 1 (each within the scatter of the next, the first and the last beyond it).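

In this assay, chloro in place of hydrogen on an aromatic carbon, ortho to a large group, meta to one chloro group and para to the other, turns 3,4-dichlorophenyl into 2,4,5-trichlorophenyl, and this step stays within the scatter (a 1.9-fold higher number from compound 3 to compound 4 (0.28 log units; within the scatter)), so a third chlorine at this position brings no readable change in this assay. The 2,4,5-trichlorophenyl group also cannot be told apart from the 4-fluorophenyl group (a 1.0-fold lower number from compound 1 to compound 4 (0.00 log units; within the scatter)), while it does separate, modestly, from the 3,5-dimethylphenyl group (a 3.3-fold higher number from compound 2 to compound 4 (0.52 log units; beyond the scatter)), so compound 2 now stands clear of two of the other compounds, though not of compound 3. Nothing available here bears on what lies behind these numbers.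

Going by these compounds, whether this position would respond differently to a group other than chloro, such as methoxy or an amine, remains open, as does the effect of a single chloro there on an otherwise unsubstituted phenyl. Also open, on these data alone, is how these aryl groups would behave on a longer chain attached to the shared core.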